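From thiophen-3-yl to 2-hydroxyphenyl on a shared core

The source may hold more compounds than are shown below. What is called first, only, known or untested is meant among the compounds shown, and "the series" means these compounds.

Three compounds share one core and differ only in one aromatic group. In a functional assay on G-361 cells (Homo sapiens) for inhibition, with a stated time of 72 h (on this read-out higher numbers stand for weaker inhibition and lower numbers for stronger inhibition), compound 1 `NC1CCC(Nc2nc(NCc3ccc(-c4ccccc4)nc3)c3ncn(C4CCCC4)c3n2)CC1` gives 895 nM with phenyl, compound 2 `NC1CCC(Nc2nc(NCc3ccc(-c4ccco4)nc3)c3ncn(C4CCCC4)c3n2)CC1` gives 97 nM with furan-2-yl, and compound 3 `NC1CCC(Nc2nc(NCc3ccc(-c4ccsc4)nc3)c3ncn(C4CCCC4)c3n2)CC1` gives 272 nM with thiophen-3-yl. Compound 3 therefore holds the middle place, with a higher number than compound 2 and a lower one than compound 1.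

Compound 4 `NC1CCC(Nc2nc(NCc3ccc(-c4ccccc4O)nc3)c3ncn(C4CCCC4)c3n2)CC1` carries 2-hydroxyphenyl in place of thiophen-3-yl on an aromatic carbon, next to the ring nitrogen and para to a large group, a change counted as 2-hydroxyphenyl in place of thiophen-3-yl on an aromatic carbon in full.

For the measured compounds named here, three measured steps bear on this change. Furan-2-yl in place of phenyl gave a 9.2-fold lower number from compound 1 to compound 2 (0.97 log units; beyond the scatter) in this assay as its result. Thiophen-3-yl in place of phenyl gave a 3.3-fold lower number from compound 1 to compound 3 (0.52 log units; beyond the scatter) as its result, and thiophen-3-yl in place of furan-2-yl gave a 2.8-fold higher number from compound 2 to compound 3 (0.45 log units; beyond the scatter) as its result. All three are modest but beyond the scatter.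

Going by the values given here, compound 4 returns to a six-membered aromatic ring of carbon only, like compound 1 at 895 nM in the same test, but no measured compound carries a hydroxy group. A small rise that stays within the scatter is expected, estimated as a 1.5-fold higher number from compound 3 to compound 4 (0.17 log units; within the scatter) for this change. The estimate for compound 4 is 400 nM with 120 nM to 1300 nM as the expected range.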

Compound 4, half-maximal inhibitory concentration: 24 nM
For compound 4 the middle estimate is 17-fold (1.22 log units) above the measured one; the whole stated range lies above it.
By their numbers in this assay, from the lowest: compound 4; then compound 2; then compound 3; then compound 1.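

In this assay the phenyl group stood at the highest number of the earlier three compounds, yet a single hydroxy group on that ring gives a 37-fold lower number from compound 1 to compound 4 (1.57 log units; beyond the scatter), the widest step seen at this position. The earlier compounds shown here suggested that five-membered rings gave lower numbers here than a six-membered aromatic ring of carbon only, but 2-hydroxyphenyl passes both of them, with an 11-fold lower number from compound 3 to compound 4 (1.05 log units; beyond the scatter) and a 4.0-fold lower number from compound 2 to compound 4 (0.61 log units; beyond the scatter), and all of these steps lie beyond the scatter, so the ring type alone does not set the number at this position. Nothing at hand explains why one added hydroxy group changes the number so much.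

Whether the low number depends on the hydroxy group itself stays open, since the compounds shown do not include 2-methoxyphenyl or 2-aminophenyl at this position. As far as these compounds go, it is also open whether a hydroxy group would lower the number on a five-membered ring such as the furan-2-yl of compound 2, or whether the step belongs to the phenyl ring alone.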